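The compounds below may be only part of what the source reports. "The series", "measured", "known", "first", "only" and "open" are said of these compounds alone.

Measured so far in a functional assay on SMMC-7721 cells (Homo sapiens) for antiproliferative activity, read by CCK-8 assay, with a stated time of 72 h; a higher number here means a weaker inhibitor, a lower number a stronger inhibitor:
- compound 1 `Nc1ccccc1NC(=O)c1ccc(CSC(=S)N2CCc3ccccc32)cc1`: 3040 nM
- compound 2 `CC1CCCCN1C(=S)SCc1ccc(C(=O)Nc2ccccc2N)cc1`: 2950 nM
- compound 3 `CCN(Cc1ccncc1)C(=S)SCc1ccc(C(=O)Nc2ccccc2N)cc1`: 1210 nM

Compound 1 sits level with compound 2, as shown by a 1.0-fold lower number from compound 1 to compound 2 (0.01 log units; within the scatter). Compound 3 stands apart from it, with a 2.5-fold lower number from compound 1 to compound 3 (0.40 log units; beyond the scatter), and likewise from compound 2, with a 2.4-fold lower number from compound 2 to compound 3 (0.39 log units; beyond the scatter).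

Compound 4 `COC(=O)c1ccc2c(c1)CCN2C(=S)SCc1ccc(C(=O)Nc2ccccc2N)cc1` keeps the core of compound 1 and gains one group: methoxycarbonyl in place of hydrogen on an aromatic carbon. In words, this is methoxycarbonyl in place of hydrogen on an aromatic carbon, part of a fused or bridged system of two rings.

Among the measured compounds shown here, no measured step adds a group at such a place. Each of them swaps the entire group on the thiocarbonyl carbon, so they offer only a loose guide. Those swaps moved the number little or modestly, so a large shift in this assay seems unlikely, and no clear direction can be read from them.

The expected change is a 1.1-fold lower number from compound 1 to compound 4 (0.05 log units; within the scatter), which is no step beyond the scatter. For compound 4 the estimated value is 2700 nM, with an expected range from 1000 nM to 7000 nM.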

Compound 4, half-maximal inhibitory concentration: > 32000 nM
Compound 4: a limit, no number; the forecaster's own chance of this, stated with the estimate: 3%; middle value at least 11-fold (1.07 log units) away from the limit.
By their numbers in this assay, from the lowest: compound 3; then compounds 2 and 1 (each within the scatter of the next). At a limit, above all of these: compound 4.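

In this assay, placing methoxycarbonyl on an aromatic carbon that is part of a fused or bridged system of two rings gives an at least 10-fold higher number from compound 1 to compound 4 (1.02 log units; beyond the scatter). The earlier steps shown here each swapped the entire group on the thiocarbonyl carbon and stayed modest or within the scatter, whereas this single added group at one aromatic carbon moves the number much further, so activity here depends strongly on what this position carries. Compound 4 gives a limit and not a number: the limit of > 32000 nM in this assay, at which 1 of the 4 values shown sits.

Methoxycarbonyl is the only group shown at this place, so the compounds leave open whether the drop belongs to this particular group or would follow any addition there. A methyl, a fluorine, an amine or a carboxylic acid on the same carbon would help separate these two readings.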